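Working notes: from compound 2 to compound 4

The source may hold more compounds than are shown below. What is called first, only, known or untested is meant among the compounds shown, and "the series" means these compounds.

Values in an ADME assay on the whole organism (Mus musculus, strain ICR(CD-1)) for pharmacokinetics, read by mass spectrometry, at a dose of 10 mg/kg by the oral route; a higher number here means more compound in the circulation at the dose given, a lower number less compound in the circulation

- compound 1 `Cc1ccc(C(=O)Nc2cccc(C(F)(F)F)c2)cc1-c1ccc2c(-c3cnn(C)c3)n[nH]c2c1` gives 3480 ng.h/mL
- compound 2 `Cc1ccc(C(=O)Nc2cccc(C(F)(F)F)c2)cc1-c1ccc2c(-c3cnn(C4CC4)c3)n[nH]c2c1` gives 7640 ng.h/mL
- compound 3 `Cc1ccc(C(=O)Nc2cccc(C(F)(F)F)c2)cc1-c1ccc2c(-c3cnn(C4CCN(C)CC4)c3)n[nH]c2c1` gives 552 ng.h/mL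

Compound 2 stands highest of the three, and its gaps to the other two lie beyond the scatter. The next compound, compound 4 `Cc1ccc(C(=O)Nc2cc(CN3CCN(C)CC3)cc(C(F)(F)F)c2)cc1-c1ccc2c(-c3cnn(C4CC4)c3)n[nH]c2c1`, has not been measured. It differs from compound 2 as follows: (4-methylpiperazin-1-yl)methyl in place of hydrogen on an aromatic carbon. In words, (4-methylpiperazin-1-yl)methyl stands in place of hydrogen on an aromatic carbon, meta to a trifluoromethyl group.

Going by the values given here, no measured step touches that place, as all three changes sit on an aromatic nitrogen. The closest guide is a 14-fold lower number from compound 2 to compound 3 (1.14 log units; beyond the scatter), with 1-methylpiperidin-4-yl entering, and a 6.3-fold lower number from compound 1 to compound 3 (0.80 log units; beyond the scatter) points the same way. Both rest on compound 3 alone. The step of a 2.2-fold higher number from compound 1 to compound 2 (0.34 log units; beyond the scatter) involves a smaller group and bears little on this change. A modest to large drop is therefore expected in this assay, with wide uncertainty. The expected step is a 4.2-fold lower number from compound 2 to compound 4 (0.63 log units; beyond the scatter). For compound 4 the estimated value is 1800 ng.h/mL, with an expected range from 450 ng.h/mL to 6000 ng.h/mL.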

Compound 4, area under the concentration-time curve in the Mus musculus assay: 66.2 ng.h/mL
The estimate for compound 4 lay 27-fold (1.43 log units) above the measured number; the measured number lies below the stated range.
By their numbers in the Mus musculus assay, from the lowest: compound 4; then compound 3; then compound 1; then compound 2.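

The aromatic carbon meta to a trifluoromethyl group is new ground, and in the Mus musculus assay (4-methylpiperazin-1-yl)methyl at this place gives a 120-fold lower number from compound 2 to compound 4 (2.06 log units; beyond the scatter). That drop is larger than the one seen on the aromatic nitrogen, where the Mus musculus assay gives a 14-fold lower number from compound 2 to compound 3 (1.14 log units; beyond the scatter). In a physicochemical assay for solubility (a lower number here means a less soluble compound, a higher number a more soluble compound), compound 2 gives 2000 nM and compound 4 gives 10000 nM. The same change moves solubility the opposite way, so in this pair a gain in solubility does not come with more compound in the circulation: the measured solubility of compound 2, 2000 nM, and of compound 4, 10000 nM, a 5.0-fold higher number (0.70 log units; beyond the scatter)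

The compounds shown do not tell whether the loss in the Mus musculus assay follows the piperazine ring, the methylene link or any substitution at this carbon, nor what drives it. A morpholine or a dimethylamino group on the same methylene, or a lone fluorine at that carbon, would help to separate these.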